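Dropping one prenylated phenol from compound 3

The source may report more compounds than this note shows. Statements on the series, on what has been measured and on what is new or still open speak of the compounds shown alone.

Values in a functional assay on HCC1806 cells (Homo sapiens) for antiproliferative activity, read by CCK-8 assay, with a stated time of 24 h; a lower number here means a stronger inhibitor, a higher number a weaker inhibitor:
- Compound 1 `COC(=O)[C@]1(Cc2ccc3c(c2)CC(O)C(C)(C)O3)OC(=O)C(O)=C1c1ccccc1`: > 20000 nM (a limit of the assay)
- Compound 2 `COC(=O)[C@]1(Cc2ccc3c(c2)CC(C(C)(C)O)O3)OC(=O)C(O)=C1c1ccccc1`: > 20000 nM (a limit of the assay)
- Compound 3 `COC(=O)[C@]1(Cc2ccc(O)c(CC=C(C)C)c2)OC(=O)C(O)=C1c1ccc(O)c(CC=C(C)C)c1`: 17600 nM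

For the measured compounds named here, compound 3, at 17600 nM, holds the only actual number in this set. Compound 4 `COC(=O)[C@]1(Cc2ccc(O)c(CC=C(C)C)c2)OC(=O)C(O)=C1c1ccccc1` has phenyl in place of 4-hydroxy-3-(3-methylbut-2-en-1-yl)phenyl on a double-bonded ring carbon. Going by the values given here, no measured step isolates this change. Compound 1 also carries phenyl at that place, and its > 20000 nM is a limit of the assay. Compound 2 also carries phenyl there, and its > 20000 nM is likewise a limit. A modest weakening in this assay is therefore expected, possibly no larger than the scatter, and estimated as a 1.4-fold higher number from compound 3 to compound 4 (0.15 log units; within the scatter). The estimate for compound 4 is 25000 nM, with an expected range of 12000 nM to 50000 nM.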

Compound 4, half-maximal inhibitory concentration: 18700 nM
The estimate for compound 4 lay 1.3-fold (0.13 log units) above the measured number; low and high end bracket the measured number.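

In this assay, phenyl in place of 4-hydroxy-3-(3-methylbut-2-en-1-yl)phenyl on the double-bonded ring carbon gives a 1.1-fold higher number from compound 3 to compound 4 (0.03 log units; within the scatter), so this position gives up that whole group without a readable change. Both values lie close to the top of the readable range, which limits what this step can say about the position: the limit of > 20000 nM in this assay, at which 2 of the 4 values shown sit.

Open, on these data alone, is whether an amine or a carboxylic acid on this phenyl would shift the number. Also open, as far as these compounds go, is whether this position matters in a compound with a much lower number.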